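Compound 3 to compound 4: a new group on the carbonyl

A few compounds are considered here, and "the series" means these few. Any claim that something is new, unique, unknown or untested is made for them only; others in the source may bear on it.

In a functional assay on HT-29 cells (Homo sapiens) for inhibition, read by MTT assay, with a stated time of 120 h (on this read-out higher numbers stand for weaker inhibition and lower numbers for stronger inhibition), compound 3 `C/C(=C\C(=O)N1CC(C)OC(C)C1)c1ccc(NC(=O)Nc2ccc(Cl)c(C(F)(F)F)c2)cc1` gives 26200 nM, within the scatter of compound 1 `CNC(=O)c1cccc(-c2ccc(NC(=O)Nc3ccc(Cl)c(C(F)(F)F)c3)cc2)c1` at 29300 nM and of compound 2 `CNC(=O)CCc1ccc(NC(=O)Nc2ccc(Cl)c(C(F)(F)F)c2)cc1` at 20600 nM. Compound 4 `CNC(=O)/C=C(\C)c1ccc(NC(=O)Nc2ccc(Cl)c(C(F)(F)F)c2)cc1` differs from compound 3 in one place: methylamino in place of 2,6-dimethylmorpholin-4-yl on a carbonyl carbon. In words, methylamino stands in place of 2,6-dimethylmorpholin-4-yl on a carbonyl carbon. Among the compounds with values here, no measured pair makes this exact change. Within the data shown here, the only measured step, a 1.4-fold lower number from compound 1 to compound 2 (0.15 log units; within the scatter), puts 2-(methylcarbamoyl)ethyl in place of 3-(methylcarbamoyl)phenyl and stays within the scatter. The step expected in this assay is therefore no larger than the scatter, an estimated 1.2-fold lower number from compound 3 to compound 4 (0.08 log units; within the scatter). Compound 4 is expected at about 22000 nM, with an estimated range of 10000 nM to 48000 nM.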

Compound 4, half-maximal inhibitory concentration: > 50000 nM
Compound 4 ended at the assay's limit (the forecaster's own chance of this, stated with the estimate: 10%); at least 2.2-fold (0.35 log units) between middle value and limit.
By their numbers in this assay, from the lowest: compounds 2, 3 and 1 (each within the scatter of the next). At a limit, above all of these: compound 4.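

In this assay, compound 4 gives only a limit, not a number: the limit of > 50000 nM in this assay, at which 1 of the 4 values shown sits.

Placing methylamino on the carbonyl carbon gives an at least 1.9-fold higher number from compound 3 to compound 4 (0.28 log units; that floor lies within the scatter), and the change of side chain gives an at least 1.7-fold higher number from compound 1 to compound 4 (0.23 log units; that floor lies within the scatter), so neither step can yet be called a real loss. Within the data shown here, only an at least 2.4-fold higher number from compound 2 to compound 4 (0.38 log units; beyond the scatter) clears the scatter, making 1-methyl-2-(methylcarbamoyl)ethenyl in place of 2-(methylcarbamoyl)ethyl the first step with a real weakening.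

On these data alone, how far compound 4 lies beyond its limit stays open. So does what a plain amino group or a piperidin-1-yl ring on this carbonyl carbon would give.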